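Flipping One Ring Stereocentre in a Lysophosphatidylserine Analogue

The source may report more compounds than this note shows. Statements on the series, on what has been measured and on what is new or still open speak of the compounds shown alone.

Compound 1 `CCCCCCCC/C=C\CCCCCCCC(=O)OC[C@H](COC)OP(=O)(O)OC[C@H](N)C(=O)O` gives 7.5% in an assay on HEK293 cells for agonist activity at probable G-protein coupled receptor 34 (Mus musculus), with a stated time of 1 h; a higher number here means a larger maximal response, a lower number a smaller maximal response.
Compound 2 `N[C@@H](COP(=O)(O)OCCOC(=O)CCc1ccccc1OCc1cccc(Oc2ccccc2)c1)C(=O)O` gives 12.4% in this assay.
Compound 3 `CCCCCCCCCCCOc1ccccc1CCC(=O)O[C@H]1CCOC[C@H]1OP(=O)(O)OC[C@H](N)C(=O)O` gives "not active" (no number reported) in this assay, with no number attached.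

Compound 3 thus stands without a single figure: it produced no measurable response, while compound 1 and compound 2 both sit at the low end of the scale, close to each other. For the measured compounds named here, compound 4 `CCCCCCCCCCCOc1ccccc1CCC(=O)O[C@H]1CCOC[C@@H]1OP(=O)(O)OC[C@H](N)C(=O)O` keeps every atom and bond of compound 3; the only change is the two compounds have the same atoms and bonds; at least one stereo element is drawn with a configuration in one of them and without one in the other: 1 of 4 stereo elements differ; a stereocentre at a saturated ring carbon is drawn R in compound 3 and S in compound 4. Going by the values given here, no measured pair here shows what such a flip does, so nothing beyond the usual scatter can be predicted in this assay from the data alone. Given that compound 3 showed no activity and the other two analogues respond weakly, compound 4 is expected to give about 8%, within 0% to 22%.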

Compound 4, largest response reached (Emax), in percent of the reference or control that the assay uses: "not active" (no number reported)
No number was reported for compound 4; there is nothing to compare the estimate with.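

Compound 3 and compound 4 are both reported as not active in this assay, with no number attached, so no step can be read between them. Going by these compounds, whether flipping this ring stereocentre can change the response at all stays open.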